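Methyl to ethyl on compound 2: expected step

This account rests on a few compounds, and the source may have more. Where it says the series, first, only, none or still open, it means among the compounds named here.

Two compounds of this series have been run in a functional assay on PC-3 cells (Homo sapiens) for inhibition, read by MTT assay, with a stated time of 48 h; on this read-out higher numbers stand for weaker inhibition and lower numbers for stronger inhibition. Compound 1 `CCn1c(/C=C2\SC(=O)N(CC(=O)Nc3cc(C(C)(C)C)on3)C2=O)nc2ccccc21` gives in this assay only a limit, > 50000 nM, not a number. Among the compounds with values here, compound 2 `Cn1c(/C=C2\SC(=O)N(CC(=O)Nc3nc(-c4ccccc4)cs3)C2=O)nc2ccccc21` gives in this assay 39900 nM, the only number in the set so far. The other value, that of compound 1, sits at a limit: the limit of > 50000 nM in this assay, at which 1 of the 2 values shown sits. Compound 3 `CCn1c(/C=C2\SC(=O)N(CC(=O)Nc3nc(-c4ccccc4)cs3)C2=O)nc2ccccc21` is not yet measured and differs from compound 2 by methyl in place of hydrogen on a saturated chain carbon bound to an aromatic nitrogen, read one bond further out as methyl to ethyl. Within the data shown here, no measured pair in the set isolates this change, so no step size can be drawn from the data. The change is small and adds no donor or acceptor; a step from compound 2 to compound 3 of a 1.1-fold higher number from compound 2 to compound 3 (0.05 log units; within the scatter) is expected, within the scatter or only slightly weaker. Compound 3 is therefore estimated at 45000 nM, with a range from 20000 nM to 100000 nM, and a fair chance of reporting only a limit.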

Compound 3, half-maximal inhibitory concentration: > 50000 nM
Compound 3 was reported as a limit (the forecaster's own chance of this, stated with the estimate: 40%); middle value at least 1.1-fold (0.04 log units) away from the limit.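

The change from methyl to ethyl now has its first measured pair in this assay, which gives an at least 1.2-fold higher number from compound 2 to compound 3 (0.09 log units; that floor lies within the scatter). On these data alone, the value of compound 3 is a limit and not a number, so the upper size of this step stays unknown, and the pair does not separate a real loss from no change. The step between compound 1 and compound 3 cannot be read, and the set now holds more limits than numbers: the limit of > 50000 nM in this assay, at which 2 of the 3 values shown sit.

As far as these compounds go, it remains open whether a longer chain such as propyl, or an amine or a carboxylic acid carried on that chain, would return a number rather than a limit. Within the data shown here, with compound 2 as the only numerical value, the effect of replacing 4-phenyl-1,3-thiazol-2-yl on the amide-type nitrogen also remains open.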